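This account rests on a few compounds, and the source may have more. Where it says the series, first, only, none or still open, it means among the compounds named here.

Compound 2 `C/C(C=O)=C1\CC[C@](C)(O)[C@]23C[C@H](/C=C(C)/C=C/[C@@H]4[C@@H](C(C)(C)O)CC[C@@]4(C)O)O[C@H]2OCCC[C@H]13` is the starting point here. In a functional assay on BV-2 cells (Mus musculus) for inhibition, read by Griess assay, with a stated time of 24 h (on this read-out lower numbers stand for stronger inhibition and higher numbers for weaker inhibition), compound 2 gives > 10000 nM, which is a limit of the assay rather than a number. Compound 1 `CC(/C=C/[C@@H]1[C@@H](C(C)(C)O)CC[C@@]1(C)O)=C\[C@H]1C[C@@]23[C@H](OCCC[C@@H]2/C(=C(\C)C=O)CC[C@]3(C)O)O1` gives > 10000 nM in this assay, likewise a limit. Compound 3 `C=C(C)[C@H]1CC[C@@](C)(O)[C@@H]1/C=C/C(C)=C/[C@H]1C[C@@]23[C@H](OCCC[C@@H]2/C(=C(\C)C=O)CC[C@]3(C)O)O1` gives > 10000 nM, also a limit. Compound 4 `C=C(C)[C@@H]1CC[C@](C)(O)[C@H]1/C=C/C(C)=C/[C@H]1C[C@@]23[C@H](OCCC[C@@H]2/C(=C(/C)C=O)CC[C@]3(C)O)O1` has not yet been measured; it differs from compound 2 in that (2-hydroxy-2-methyl-5-(1-methylethenyl)cyclopentyl in place of 2-hydroxy-5-(1-hydroxy-1-methylethyl)-2-methylcyclopentyl on a double-bonded chain carbon bound to a double-bonded chain carbon). The closest measured step is a step that the two limits leave unreadable from compound 1 to compound 3, and the step that the two limits leave unreadable from compound 1 to compound 2 is equally unreadable, because of the limit of > 10000 nM in this assay, at which 3 of the 3 values shown sit. For the measured compounds named here, no measured step therefore shows a readable change, and compound 4 is expected to stay close to the limit, with an estimate of 15000 nM, between 7000 nM and 40000 nM, which means an expected step that the limit leaves unreadable from compound 2 to compound 4.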

Compound 4, half-maximal inhibitory concentration: > 10000 nM
Compound 4: no number, only a limit; the forecaster's own chance of this, stated with the estimate: 80%; the middle value lies beyond the limit too.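

The steps from compound 2 to compound 4 and from compound 3 to compound 4 cannot be read, because all the values are limits: the limit of > 10000 nM in this assay, at which 4 of the 4 values shown sit.

The compounds shown leave open whether changing the group or the drawn configuration affects inhibition at all.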